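A few compounds are considered here, and "the series" means these few. Any claim that something is new, unique, unknown or untested is made for them only; others in the source may bear on it.

- Compound 1 `O=C1C=C(N2CCN(c3ccccc3Cl)CC2)C(=O)c2ccccc21`: 11100 nM
- Compound 2 `O=C1C=C(N2CCN(c3ccccc3Cl)CC2)C(=O)c2c(O)cccc21`: 7700 nM
- Compound 3 `O=C1C=C(N2CCC(c3ccccc3)CC2)C(=O)c2c(O)cccc21`: 9700 nM

In a functional assay on HepG2 cells (Homo sapiens) for antiproliferative activity, read by MTT assay, with a stated time of 72 h (on this read-out higher numbers stand for weaker inhibition and lower numbers for stronger inhibition), compound 3 gives 9700 nM, which lies within the scatter of both other compounds, so the three cannot be ranked. Compound 4 `Cc1ccccc1C1CCN(C2=CC(=O)c3cccc(O)c3C2=O)CC1` differs from compound 3 by methyl in place of hydrogen on an aromatic carbon, turning phenyl to 2-methylphenyl. For the measured compounds named here, no measured step tests this methyl. Going by the values given here, the only measured step, a 1.4-fold lower number from compound 1 to compound 2 (0.16 log units; within the scatter), adds hydroxy in place of hydrogen on an aromatic carbon, so it bears only loosely, and it stayed small. No change beyond the scatter is therefore expected, and the estimated step is a 1.1-fold lower number from compound 3 to compound 4 (0.03 log units; within the scatter). For compound 4 the expected value is 9000 nM, with an estimated range of 4500 nM to 18000 nM.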

Compound 4, half-maximal inhibitory concentration: 16600 nM
Compound 4: the middle estimate sits 1.8-fold (0.27 log units) below what was measured; measured number inside the range.
By their numbers in this assay, from the lowest: compounds 2, 3, 1 and 4 (each within the scatter of the next, the first and the last beyond it).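

In this assay, methyl in place of hydrogen on the aromatic carbon ortho to a large group, turning phenyl to 2-methylphenyl, gives a 1.7-fold higher number from compound 3 to compound 4 (0.23 log units; within the scatter), the first measured test of this position. A single added carbon here therefore leaves the number within the usual scatter, so this position accepts methyl without a clear loss or gain. No measurement at hand offers an explanation for this result. Still open, from the compounds shown here alone, is whether a larger or different group at this place, such as ethyl, methoxy or an amine, would shift the number beyond the scatter.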